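The source may hold more compounds than are shown below. What is called first, only, known or untested is meant among the compounds shown, and "the series" means these compounds.

Compound 1 `COc1cc(-c2cc(/C=C/C(=O)c3ccc(N)cc3)[nH]n2)cc(OC)c1OC` and compound 2 `COc1ccc(C(=O)/C=C/c2cc(-c3cc(OC)c(OC)c(OC)c3)n[nH]2)cc1` share one core and differ in a single group. In a functional assay on MCF7 cells (Homo sapiens) for cytotoxicity, read by sulforhodamine B assay, with a stated time of 48 h, tested at 0.1 uM (a higher number here means a weaker effect of the compound at the concentration tested, a lower number a stronger effect), compound 1 gives 91%, and compound 2 gives 93%. Among the compounds with values here, the one step between them, a number 2 percentage points higher from compound 1 to compound 2 (within the scatter), came with methoxy in place of amino on an aromatic carbon. Compound 2 and compound 1 thus sit within the scatter of each other, so neither can be set above the other, and both leave most cells unaffected at this concentration.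

Within the data shown here, compound 3 `COc1cc(-c2cc(/C=C/C(=O)c3ccc(F)c(F)c3)[nH]n2)cc(OC)c1OC` is the next compound. 3,4-difluorophenyl in place of 4-methoxyphenyl on a carbonyl carbon No measured step touches this place or this kind of exchange; the only known step changed a different group and was itself within the scatter. Nothing therefore points to a move beyond the scatter, and compound 3 is expected to give 91% in this assay, with a range from 72% to 102%. This estimate means that a number 2 percentage points lower from compound 2 to compound 3 (within the scatter) is expected.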

Compound 3, a percentage reported as activity, at one concentration (the size of the read-out at that concentration, not a potency): 98%
The estimate for compound 3 lay 7 percentage points below the measured number, and the stated range covers the measured number.
By their numbers in this assay, from the lowest: compounds 1, 2 and 3 (each within the scatter of the next).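

In this assay, putting 3,4-difluorophenyl on the carbonyl carbon in place of 4-methoxyphenyl gives a number 5 percentage points higher from compound 2 to compound 3 (within the scatter), and putting it there in place of 4-aminophenyl gives a number 7 percentage points higher from compound 1 to compound 3 (within the scatter). So this place has now taken three different groups, and even the exchange that removes the hydrogen-bond acceptor counted on 4-methoxyphenyl and brings in two fluorines does not move the read-out beyond the scatter at this one concentration. Nothing at hand explains this result or says what these groups do in the cells.

All three compounds have numbers that lie within the scatter of one another, so no ranking among these groups can be read from them. Going by these compounds, whether a carboxylic acid or a longer chain on this carbonyl carbon, in place of the substituted phenyl ring, would give a step beyond the scatter remains open.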